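Extending the Ether Chain on a Shared Core

The compounds below may be only part of what the source reports. "The series", "measured", "known", "first", "only" and "open" are said of these compounds alone.

Of the compounds shown here, two on a shared core have been measured so far. Compound 1 `COCCOCCOCCOCCOCCOCCOCC(=O)Oc1c(C(C)C)cccc1C(C)C` gives 110000 nM in an ADME assay on L929 cells (Mus musculus) for cytotoxicity, read by MTT assay, with a stated time of 24 h; a higher number here means that more compound is needed for the effect, a lower number that less compound is needed. Compound 2 `COCCOCCOCCOCCOCCOCCOC(=O)Oc1c(C(C)C)cccc1C(C)C` gives 510000 nM in this assay, the higher of the two numbers, and the gap between compound 1 and compound 2 lies beyond the usual scatter. Compound 3 `COCCOCCOCCOCCOCCOCCOCCOC(=O)Oc1c(C(C)C)cccc1C(C)C` is not yet measured; it differs from compound 2 in one place: methoxymethyl in place of hydrogen on a saturated chain carbon bound to an oxygen on a saturated carbon. Only the far end of the chain grows, the rest of the core is unchanged. Among the measured compounds shown here, no measured pair shows this kind of change, so there is nothing to say about its size from data; the step from compound 2 to compound 3 is expected to be small, a 1.2-fold higher number from compound 2 to compound 3 (0.07 log units; within the scatter), likely within the scatter or a slight rise. Compound 3 is therefore estimated at 600000 nM, with a range from 220000 nM to 1600000 nM.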

Compound 3, half-maximal effective concentration: 110000 nM
Compound 3: middle estimate off by 5.5-fold (0.74 log units), on the high side; the measured number lies below the stated range.
By their numbers in this assay, from the lowest: compounds 1 and 3 (each within the scatter of the next); then compound 2.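

Putting methoxymethyl in place of hydrogen on a saturated chain carbon bound to an oxygen on a saturated carbon gives a 4.6-fold lower number from compound 2 to compound 3 (0.67 log units; beyond the scatter) in this assay, so less compound is needed for the effect. The far end of the chain is therefore not a silent position: a change there alone moves the number beyond the usual scatter. Still, this is a single step at this position, which gives the size and direction of one change but no trend along the chain, and nothing available explains the drop.

As far as these compounds go, whether a longer chain would keep the number this low or raise it again remains open. So does whether an amine or a carboxylic acid at the far end of the chain would shift the number in the same direction.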